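The source may hold more compounds than are shown below. What is called first, only, known or untested is meant among the compounds shown, and "the series" means these compounds.

Three compounds have so far been measured in a functional assay on MGC-803 cells (Homo sapiens) for antiproliferative activity, read by CCK-8 assay, with a stated time of 72 h, tested at 8 uM; a higher number here means a stronger effect of the compound at the concentration tested, a lower number a weaker effect:

Compound 1 `Nc1ccccc1NC(=O)c1ccc(CSC(=S)N2CCc3cc([N+](=O)[O-])ccc32)cc1`: 33.2%
Compound 2 `Nc1ccccc1NC(=O)c1ccc(CSC(=S)N2CCc3ccc([N+](=O)[O-])cc32)cc1`: 39.6%
Compound 3 `CC1CCN(C(=S)SCc2ccc(C(=O)Nc3ccccc3N)cc2)CC1`: 81.9%

Compound 3 stands highest of these three numbers. Its nearest neighbour is compound 2, whose number is lower by a gap beyond the usual scatter, and compound 1 lies further below, also beyond the scatter. All three share the same core, and they differ only in the group attached to the thiocarbonyl carbon.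

The next compound to be tested, compound 4 `CN(Cc1ccncc1)C(=S)SCc1ccc(C(=O)Nc2ccccc2N)cc1`, keeps that core and changes the same position once more: methyl((pyridin-4-yl)methyl)amino in place of 4-methylpiperidin-1-yl on a thiocarbonyl carbon. A saturated six-membered ring with one nitrogen gives way to an open methyl-bearing nitrogen carrying a pyridin-4-ylmethyl group, so the count of heavy atoms rises by two and one hydrogen-bond acceptor comes in.

Among the compounds with values here, no measured pair differs in exactly this way, so there is no step of the same kind to lean on. Within the data shown here, the only guidance is that compound 3, with its 4-methylpiperidin-1-yl group, gives 81.9% while the two compounds with other groups at this position sit far lower. On that basis the step of a number 19.9 percentage points lower from compound 3 to compound 4 (beyond the scatter) is expected to be a decrease, probably beyond the scatter, though with wide uncertainty. Compound 4 is therefore estimated to give 62%, within a range from 35% to 85%.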

Compound 4, a percentage reported as inhibition, at one concentration (the size of the read-out at that concentration, not a potency): 83.2%
The estimate for compound 4 lay 21.2 percentage points below the measured number, within the range that was stated.
By their numbers in this assay, from the lowest: compounds 1 and 2 (each within the scatter of the next); then compounds 3 and 4 (each within the scatter of the next).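

In this assay the change gives a number 1.3 percentage points higher from compound 3 to compound 4 (within the scatter), so the read-out does not separate methyl((pyridin-4-yl)methyl)amino from 4-methylpiperidin-1-yl on a thiocarbonyl carbon. The high number of compound 3 is therefore not tied to one group: a six-membered non-aromatic ring and an open methyl-bearing nitrogen with a pyridin-4-ylmethyl group both sit at this level, although this does not extend to every group at the position, since compound 1 gives 33.2% and compound 2 gives 39.6%. Nothing available explains why these two quite different groups give matching read-outs.

The compounds shown cannot tell whether the nitrogen in the aromatic ring matters, and a plain benzyl group in place of pyridin-4-ylmethyl, or a morpholin-4-yl group in place of 4-methylpiperidin-1-yl, would help to settle what this position accepts. From the compounds shown here alone, since each read-out comes from a single concentration, it also remains open whether compound 3 and compound 4 would match in potency across a full range of concentrations.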